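Removing a Fluorine: Expected Cytotoxicity of Compound 4

The source may report more compounds than this note shows. Statements on the series, on what has been measured and on what is new or still open speak of the compounds shown alone.

Compound 1 `CCOc1ccc2nc(Nc3nc4ccc(F)cc4s3)sc2c1` gives 26600 nM in a functional assay on U-937 cells (Homo sapiens) for cytotoxicity, read by MTT assay, with a stated time of 48 h; a lower number here means a stronger inhibitor, a higher number a weaker inhibitor. Two related compounds have also been tested: compound 2 `Fc1ccc(NC(=S)Nc2nc3ccccc3s2)cc1` gives 32100 nM, and compound 3 `Fc1ccc(NC(=S)Nc2nc3ccc(F)cc3s2)cc1` gives 16200 nM in this assay. How the core of compound 1 differs from the core of compound 3 is not broken down here. Between compound 3 and compound 2 the change is hydrogen in place of fluoro on an aromatic carbon, and it produced a 2.0-fold higher number from compound 3 to compound 2 (0.30 log units; within the scatter). Compound 4 `CCOc1ccc2nc(Nc3nc4ccccc4s3)sc2c1` has not yet been measured; it differs from compound 1 by hydrogen in place of fluoro on an aromatic carbon, the same change at the same place. Compound 4 is therefore expected to show an estimated 1.5-fold higher number from compound 1 to compound 4 (0.18 log units; within the scatter) in this assay, because a 2.0-fold higher number from compound 3 to compound 2 (0.30 log units; within the scatter) stayed within the scatter. The estimate for compound 4 is 40000 nM, expected to fall between 15000 nM and 110000 nM.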

Compound 4, half-maximal inhibitory concentration: > 50000 nM
Compound 4: a limit, no number; the forecaster's own chance of this, stated with the estimate: 10%; at least 1.2-fold (0.09 log units) between middle value and limit.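

In this assay compound 4 gives > 50000 nM, which is a limit of the assay and not a number. Hydrogen in place of fluoro on the core of compound 1 therefore gives an at least 1.8-fold higher number from compound 1 to compound 4 (0.27 log units; that floor lies within the scatter), a floor and not a full measure of the step. This shows only how far the two cores can be compared, not that the change carries over with the same size: the same change on two cores in this assay, a 2.0-fold higher number (0.30 log units; within the scatter) from compound 3 to compound 2 and an at least 1.8-fold higher number (0.27 log units; that floor lies within the scatter) from compound 1 to compound 4; the limit leaves it open whether they differ

The compounds shown leave open how other groups at this place, such as chloro or an amine, would read in this assay. Such groups on the core of compound 1 could show whether values there stay clear of the limit.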